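The compounds below may be only part of what the source reports. "The series", "measured", "known", "first", "only" and "open" are said of these compounds alone.

Measured compounds:
compound 1 `CC(=O)Nc1ccc(S(=O)(=O)NNC(=O)c2cccnc2Nc2ccc(Cl)cc2)cc1` — > 100000 nM
compound 2 `O=C(NNS(=O)(=O)c1ccc(F)cc1)c1cccnc1Nc1ccc(Cl)cc1Cl` — > 100000 nM

Compound 1 `CC(=O)Nc1ccc(S(=O)(=O)NNC(=O)c2cccnc2Nc2ccc(Cl)cc2)cc1` was tested in a functional assay on SF-268 cells (Homo sapiens) for antiproliferative activity (on this read-out higher numbers stand for weaker inhibition of growth and lower numbers for stronger inhibition of growth), and gives > 100000 nM, which is a limit of the assay and not a measured number. Compound 2 `O=C(NNS(=O)(=O)c1ccc(F)cc1)c1cccnc1Nc1ccc(Cl)cc1Cl` gives in this assay the value > 100000 nM, again only a limit. Among the measured compounds shown here, both values therefore sit at the limit of > 100000 nM in this assay, at which 2 of the 2 values shown sit, so compound 1 stands at the same limit as the only other compound, and no step between measured compounds can be given.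

Compound 3 `O=C(NNS(=O)(=O)c1ccc(Cl)cc1Cl)c1cccnc1Nc1ccc(Cl)cc1` is not yet measured. It differs from compound 1 in one place: 2,4-dichlorophenyl in place of 4-acetamidophenyl on a sulfonyl sulfur. For the measured compounds named here, with both known compounds at the limit, there is no measured step to build on, and the change has no precedent among them. The expectation is that compound 3 behaves like compound 1, with no step beyond the usual scatter and a fair chance of another limit. The estimated step of a number no higher from compound 1 to compound 3 (the limit leaves the size open) is accordingly close to none. Compound 3 is expected to give in this assay about 100000 nM, within a range from 30000 nM to 300000 nM.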

Compound 3, concentration for total growth inhibition: 100000 nM
Beside the measured number, compound 3's estimate shows no gap at the digits printed, within the range that was stated.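

In this assay compound 3 gives 100000 nM, which is a measured number and not a limit, so a sulfonyl sulfur carrying 2,4-dichlorophenyl gives a readable value on this core. Compound 1 gives > 100000 nM, which is a limit of the assay. Replacing 4-acetamidophenyl with 2,4-dichlorophenyl on the sulfonyl sulfur therefore gives a number no higher from compound 1 to compound 3 (the limit leaves the size open), and this step shows only a direction that is allowed, with most of the values shown still resting on the same limit: the limit of > 100000 nM in this assay, at which 2 of the 3 values shown sit.

The compounds shown leave open whether any group on this sulfonyl sulfur can bring a value clearly under that limit, since none of them yet does. A phenyl ring carrying an amine or a carboxylic acid, or a longer alkyl chain in place of the ring, would test whether this position matters at all for growth inhibition of these cells.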